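Swapping a Ring for a Chain

The compounds below may be only part of what the source reports. "The series", "measured", "known", "first", "only" and "open" are said of these compounds alone.

In a functional assay on MCF7 cells (Homo sapiens) for antiproliferative activity, read by sulforhodamine B assay, with a stated time of 48 h (a higher number here means a weaker inhibitor, a lower number a stronger inhibitor), compound 1 (`O=C1NCCN1c1ccc(S(=O)(=O)Nc2ccc3[nH]ccc3c2)cc1`) gives 170 nM. Compound 2 (`O=C1NCCN1c1ccc(S(=O)(=O)Nc2ccc(C3CCCCC3)cc2)cc1`) gives only a limit, > 1000 nM, and not an exact number. Compound 3 (`CCCCCCCc1ccc(NS(=O)(=O)c2ccc(N3CCNC3=O)cc2)cc1`) keeps the shared core but has heptyl in place of cyclohexyl on an aromatic carbon, para to a large group: heptyl in place of cyclohexyl on an aromatic carbon. The ring is opened out into a chain of similar size. Among the compounds with values here, no measured pair tests this kind of swap. The expected change is small and no larger than the scatter, in either direction: a step that the limit leaves unreadable from compound 2 to compound 3. For compound 3, the estimated value is 1500 nM, with an expected range from 400 nM to 6000 nM.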

Compound 3, half-maximal inhibitory concentration: > 1000 nM
Compound 3: no number, only a limit (the forecaster's own chance of this, stated with the estimate: 50%); the middle value does not contradict the limit.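

Compound 2 and compound 3 each give only a limit and not a number, so no step can be read between them because of this: the limit of > 1000 nM in this assay, at which 2 of the 3 values shown sit.

As far as these compounds go, whether heptyl and cyclohexyl differ in strength at all stays open.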